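Compound 3: isopentyl in place of 4-nitrophenyl

The source may hold more compounds than are shown below. What is called first, only, known or untested is meant among the compounds shown, and "the series" means these compounds.

Compound 1 `C[C@H]1O[C@@H](n2cc(F)c(NC(=O)Oc3ccc([N+](=O)[O-])cc3)nc2=O)[C@@H]2OC(=O)O[C@@H]21` gives 30 ug/mL
Compound 2 `C[C@H]1O[C@@H](n2cc(F)c(NC(=O)Oc3ccc([N+](=O)[O-])cc3)nc2=O)[C@H](O)[C@@H]1O` gives 10 ug/mL

Both numbers come from a functional assay on HeLa cells (Homo sapiens) for cytotoxicity, read by MTT assay, with a stated time of 3 days (a higher number here means a weaker inhibitor, a lower number a stronger inhibitor), and compound 2 holds the lower of the two, which makes it the stronger inhibitor of this pair. The next compound to be tested is compound 3 `CC(C)CCOC(=O)Nc1nc(=O)n([C@@H]2O[C@H](C)[C@@H](O)[C@H]2O)cc1F` which has isopentyl in place of 4-nitrophenyl on an oxygen next to a carbonyl group. For the measured compounds named here, only one measured step exists (a 3.0-fold lower number from compound 1 to compound 2 (0.48 log units; beyond the scatter)) and it was modest. That step changed the group on an aromatic nitrogen, not the group that changes now. It therefore bears only indirectly, as a rough guide to how far a single change on the shared core has moved the number. Going by the values given here, no measured compound carries isopentyl, so the data do not settle the direction. A modest step is expected, with a cautious lean toward a higher number, which would mean a weaker inhibitor. The estimated change is a 2.5-fold higher number from compound 2 to compound 3 (0.40 log units; beyond the scatter) and it remains uncertain. In this assay compound 3 is expected to give 25 ug/mL with an estimated range from 6 ug/mL to 100 ug/mL once it is measured.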

Compound 3, half-maximal inhibitory concentration: 90 ug/mL
The estimate for compound 3 lay 3.6-fold (0.56 log units) below the measured number, within the range that was stated.
By their numbers in this assay, from the lowest: compound 2; then compound 1; then compound 3.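

In this assay, for the compounds shown here, isopentyl in place of 4-nitrophenyl on an oxygen next to a carbonyl group gives a 9.0-fold higher number from compound 2 to compound 3 (0.95 log units; beyond the scatter) and so a weaker inhibitor, the first sign that the group at this position affects the number. Going by these compounds alone, the only earlier step, a 3.0-fold lower number from compound 1 to compound 2 (0.48 log units; beyond the scatter), changed the group on an aromatic nitrogen, so it said nothing about this oxygen. The change replaces a group with one six-membered aromatic ring and 2 hydrogen-bond acceptors by one with no ring and no acceptors, and nothing measured here explains why the number rose.

This single step cannot separate the loss of the ring from the loss of the nitro group or from the smaller number of heavy atoms, and a plain phenyl group or a longer chain such as octyl on the same oxygen would help to tell these apart. As far as these compounds go, it also remains open whether isopentyl would have a similar effect on the core of compound 1, with its additional five-membered ring.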